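Carrying One Ether Swap Onto a Second Core

The source may report more compounds than this note shows. Statements on the series, on what has been measured and on what is new or still open speak of the compounds shown alone.

Compound 1, `Cc1ccc(Oc2ccc3nc(COc4cccc(C(=O)O)c4)n(C)c3n2)cc1`, gives 12.6 10^-6 cm/s in an ADME assay for permeability, using PAMPA, with a stated time of 4 h; a lower number here means that the compound crosses the layer more slowly, a higher number that the compound crosses the layer faster.
Compound 2, `Cn1c(COc2cccc(C(=O)O)c2)nc2ccc(Oc3ccc4c(c3)OCC4)nc21`, gives 9.1 10^-6 cm/s in this assay.
Compound 3, `Cc1ccc(Oc2cc3c(cn2)nc(COc2cccc(C(=O)O)c2)n3C)cc1`, gives 6.8 10^-6 cm/s in this assay.

Compound 2 differs from compound 1 by one exchange on the group that sits on the oxygen on an aromatic ring: a group of 9 heavy atoms (8 carbon, 1 oxygen; one five-membered non-aromatic ring with 1 hetero atom, one six-membered aromatic ring of carbon only) in place of a group of 7 heavy atoms (7 carbon; one six-membered aromatic ring of carbon only), on an oxygen on an aromatic ring. That exchange made a step of a 1.4-fold lower number from compound 1 to compound 2 (0.14 log units; within the scatter). Compound 3 has the same atoms as compound 1, joined differently; the difference between the two cores is not broken down here. The unmeasured compound 4, `Cn1c(COc2cccc(C(=O)O)c2)nc2cnc(Oc3ccc4c(c3)OCC4)cc21`, carries the same change, at the same place, on the core of compound 3: a group of 9 heavy atoms (8 carbon, 1 oxygen; one five-membered non-aromatic ring with 1 hetero atom, one six-membered aromatic ring of carbon only) in place of a group of 7 heavy atoms (7 carbon; one six-membered aromatic ring of carbon only), on an oxygen on an aromatic ring. For the measured compounds named here, compound 3 sits with the lowest of the three numbers so far, though all three lie within the usual scatter of one another. The expected step to compound 4 is estimated as a 1.4-fold lower number from compound 3 to compound 4 (0.14 log units; within the scatter). Going by the values given here, that expectation rests on the single earlier pair, where the step was a 1.4-fold lower number from compound 1 to compound 2 (0.14 log units; within the scatter), so the range is kept wide. Compound 4 is therefore expected to give about 4.9 10^-6 cm/s in this assay, with an estimated range from 2.8 10^-6 cm/s to 8.5 10^-6 cm/s.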

Compound 4, apparent permeability in the ADME assay: 3.6 10^-6 cm/s
For compound 4 the middle estimate is 1.4-fold (0.13 log units) above the measured one, within the range that was stated.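

In the ADME assay, compound 3 gives 6.8 10^-6 cm/s and compound 4 gives 3.6 10^-6 cm/s; putting the new group with its five-membered non-aromatic ring in place of 4-methylphenyl gave a 1.9-fold lower number from compound 3 to compound 4 (0.28 log units; within the scatter). Set beside the earlier step, the same change behaves alike on the two cores, with no difference that can be told from the scatter: the same change on two cores in the ADME assay, a 1.4-fold lower number (0.14 log units; within the scatter) from compound 1 to compound 2 and a 1.9-fold lower number (0.28 log units; within the scatter) from compound 3 to compound 4, 1.4-fold (0.13 log units) apart, within the scatter of two such steps. Both steps lie within the scatter, so this shows agreement across two cores only, not a real shift on either one, and it says nothing of other cores in the series; in a physicochemical assay for solubility, read by HPLC, measured as thermodynamic solubility, with a stated time of 4 h, at pH 6.8 (on this read-out lower numbers stand for lower solubility and higher numbers for higher solubility), compound 3 gives 360 ug/mL and compound 4 gives 79 ug/mL, and the same exchange gave a 4.6-fold lower number from compound 3 to compound 4 (0.66 log units; beyond the scatter), a step shown on this one core alone.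

On these data alone, whether that step in the physicochemical assay would repeat on the core of compound 1 stays open. Also open, as far as these compounds go, is how a different group on the same oxygen, such as a phenyl ring carrying an amine or a longer carbon chain, would behave on either core.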